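The compounds below may be only part of what the source reports. "The series", "measured", "known", "first", "only" and "open" are said of these compounds alone.

Compound 1 `Cc1cnc(NC(=O)c2cc(Oc3cnc(C(=O)N4CCC4)cn3)c3cc(C)oc3c2)cn1` gives 10000 nM
Compound 2 `Cc1cnc(NC(=O)c2cc(Oc3cnc(C(=O)N4CCCC4)cn3)c3cc(C)oc3c2)cn1` gives 4500 nM

In a physicochemical assay for solubility, measured as kinetic solubility (on this read-out higher numbers stand for higher solubility and lower numbers for lower solubility), compound 2 stands lowest of the two measured compounds, at 4500 nM. Compound 3 `Cc1cnc(NC(=O)c2cc(Oc3cnc(C(=O)N4CCCCC4)cn3)c3cc(C)oc3c2)cn1` differs from it in one place: piperidin-1-yl in place of pyrrolidin-1-yl on a carbonyl carbon. Among the measured compounds shown here, only one measured step bears on this change, a similar swap on a carbonyl carbon: a 2.2-fold lower number from compound 1 to compound 2 (0.35 log units; beyond the scatter). One step is thin evidence, but it points to another modest fall in this assay rather than to no change. The expected step is a 2.1-fold lower number from compound 2 to compound 3 (0.33 log units; beyond the scatter). For compound 3 the estimated value is 2100 nM, with an expected range from 800 nM to 5000 nM.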

Compound 3, solubility: 24000 nM
Compound 3: middle estimate off by 11-fold (1.06 log units), on the low side; measured number outside the range, above it.
By their numbers in this assay, from the lowest: compound 2; then compound 1; then compound 3.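

In this assay, the size of the ring on the carbonyl carbon does not push the number one way: the earlier fall reverses, with a 5.3-fold higher number from compound 2 to compound 3 (0.73 log units; beyond the scatter) on going to piperidin-1-yl. Piperidin-1-yl also ends higher than azetidin-1-yl, with a 2.4-fold higher number from compound 1 to compound 3 (0.38 log units; beyond the scatter) for that swap, so compound 2 is the low point of the three. Nothing measured here explains this turn.

From the compounds shown here alone, whether the rise holds for a larger ring such as azepan-1-yl, or for morpholin-4-yl with its ring oxygen, stays open. So does whether an open-chain dimethylamino group on the same carbonyl carbon would follow the ring compounds.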